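A few compounds are considered here, and "the series" means these few. Any claim that something is new, unique, unknown or untested is made for them only; others in the source may bear on it.

In an ADME assay on L6 cells (Rattus norvegicus) for cytotoxicity, read by resazurin assay, with a stated time of 72 h (on this read-out lower numbers stand for stronger inhibition and higher numbers for weaker inhibition), compound 1 (`CN1CCN(CCC(=O)N2CCC3(N(C)C)CC(c4ccccc4)C2C(c2ccccc2)C3)CC1`) gives 128000 nM and compound 2 (`CN1CCN(CC(=O)N2CCC3(N(C)C)CC(c4ccccc4)C2C(c2ccccc2)C3)CC1`) gives 195000 nM, so compound 1 sits level with compound 2 within the scatter. Compound 3 (`CN1CCN(CCC(=O)NC2CC3(N4CCCCC4)CC(c4ccccc4)C2C(c2ccccc2)C3)CC1`) gives a lower number, 61100 nM, and this gap to compound 1 lies beyond the scatter.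

The next compound is compound 4 (`CN1CCN(CCC(=O)N2CCC3(N4CCCC4)CC(c4ccccc4)C2C(c2ccccc2)C3)CC1`), which differs from compound 1 as follows: pyrrolidin-1-yl in place of dimethylamino on a saturated ring carbon. In short, pyrrolidin-1-yl stands in place of dimethylamino on a saturated ring carbon.

For the measured compounds named here, no measured pair isolates this change. Going by the values given here, the one measured step, a 1.5-fold higher number from compound 1 to compound 2 (0.18 log units; within the scatter), lies within the scatter, but it concerns the chain bound to the carbonyl carbon, not this ring carbon, so it bears on the change only indirectly. Compound 3 also lacks dimethylamino, but its core differs from that of compound 1 too, so its lower number cannot be assigned to the amine alone.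

A step within the scatter is therefore expected in this assay, with only a slight lean towards a lower number. The expected step is a 1.2-fold lower number from compound 1 to compound 4 (0.09 log units; within the scatter). Compound 4 is estimated at 105000 nM, with an expected range of 50000 nM to 210000 nM.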

Compound 4, half-maximal inhibitory concentration: 75400 nM
Compound 4: middle estimate off by 1.4-fold (0.14 log units), on the high side; measured number inside the range.
By their numbers in this assay, from the lowest: compounds 3, 4, 1 and 2 (each within the scatter of the next, the first and the last beyond it).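

In this assay, for the compounds shown here, this is the first measured pair that isolates a change on this saturated ring carbon, as the only earlier step concerned the chain on the carbonyl carbon. Replacing dimethylamino with pyrrolidin-1-yl adds two heavy atoms and one five-membered non-aromatic ring, and gives a 1.7-fold lower number from compound 1 to compound 4 (0.23 log units; within the scatter) on the shared core. The read-out therefore does not separate these two amines at this position, and the ring closure brings no step beyond the scatter in this single pair.

Still open, as far as these compounds go, is whether morpholin-4-yl, azepan-1-yl or an unsubstituted amino group on this ring carbon would give a step beyond the scatter, and whether the exchange of dimethylamino for pyrrolidin-1-yl gives a similar step when the shorter chain of compound 2 is present. No supporting evidence is available on what lies behind the step seen here.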